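The compounds below may be only part of what the source reports. "The series", "measured", "known", "first", "only" and "open" are said of these compounds alone.

The measured compounds are compound 1 `CCOC(=O)CCCCC/N=C(\S)N1c2c(O)nc(N)nc2NCC1CNc1ccc(C(=O)NC(CCC(=O)O)C(=O)O)cc1` and compound 2 `CCOC(=O)CCCCCC/N=C(\S)N1c2c(O)nc(N)nc2NCC1CNc1ccc(C(=O)NC(CCC(=O)O)C(=O)O)cc1`.

In a functional assay on HEp-2 cells (Homo sapiens), read by colony formation (a lower number here means a stronger inhibitor, a higher number a weaker inhibitor), compound 1 gives only a limit, > 25000 nM. Compound 2 likewise gives only a limit in this assay, > 25000 nM. Both values sit at the limit of > 25000 nM in this assay, at which 2 of the 2 values shown sit, so compound 2 stands at that limit and the step that the two limits leave unreadable from compound 1 to compound 2 has no readable size. Compound 3 `CCOC(=O)CCCCCCC/N=C(\S)N1c2c(O)nc(N)nc2NCC1CNc1ccc(C(=O)NC(CCC(=O)O)C(=O)O)cc1` differs from compound 2 by (ethoxycarbonyl)methyl in place of ethoxycarbonyl on a saturated chain carbon, six bonds along the chain from a double-bonded nitrogen. Within the data shown here, the one measured step that bears on this change, a step that the two limits leave unreadable from compound 1 to compound 2, gives no size, so no change beyond the scatter is expected in this assay. Compound 3 is therefore estimated at 50000 nM, in the range 25000 nM to 200000 nM. The expected step is a step that the limit leaves unreadable from compound 2 to compound 3, and the result is expected to remain a limit.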

Compound 3, half-maximal inhibitory concentration: > 25000 nM
Compound 3 was reported as a limit (the forecaster's own chance of this, stated with the estimate: 85%); the middle value does not contradict the limit.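

Compound 1, compound 2 and compound 3 are all reported only as limits in this assay, so no step among them can be read: the limit of > 25000 nM in this assay, at which 3 of the 3 values shown sit.

The compounds shown leave open how strongly each inhibits and whether chain length matters in this assay.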